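The source may hold more compounds than are shown below. What is called first, only, known or untested is meant among the compounds shown, and "the series" means these compounds.

Three compounds sharing one core, each carrying a different group on the same ring, have been measured in an assay on isolated protein for inhibition of Indoleamine 2,3-dioxygenase 2 (Homo sapiens); on this read-out lower numbers stand for stronger inhibition and higher numbers for weaker inhibition. Compound 1 `OCc1cn(CCNc2nonc2/C(=N/O)Nc2ccc(F)c(Br)c2)nn1` gives 794 nM, compound 2 `CCCCc1cn(CCNc2nonc2/C(=N/O)Nc2ccc(F)c(Br)c2)nn1` gives 830 nM, and compound 3 `CC(C)(C)c1cn(CCNc2nonc2/C(=N/O)Nc2ccc(F)c(Br)c2)nn1` gives 1870 nM, the highest of the three numbers. The steps of a 2.4-fold higher number from compound 1 to compound 3 (0.37 log units; beyond the scatter) and a 2.3-fold higher number from compound 2 to compound 3 (0.35 log units; beyond the scatter) are both modest and point the same way, whereas a 1.0-fold higher number from compound 1 to compound 2 (0.02 log units; within the scatter) lies within the scatter. Compound 4 `OCCc1cn(CCNc2nonc2/C(=N/O)Nc2ccc(F)c(Br)c2)nn1` differs from compound 3 in one place: 2-hydroxyethyl in place of tert-butyl on an aromatic carbon. This change is close to the reverse of the change from compound 1 to compound 3, and the two steps that lead into compound 3 both show that the tert-butyl group goes with a modestly higher number. A modest drop in this assay is therefore expected when it leaves. Compound 4 is expected to give 850 nM, with a range from 400 nM to 1800 nM, which corresponds to an expected step of a 2.2-fold lower number from compound 3 to compound 4 (0.34 log units; beyond the scatter).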

Compound 4, half-maximal inhibitory concentration: 1170 nM
Compound 4: the middle estimate sits 1.4-fold (0.14 log units) below what was measured, within the range that was stated.
By their numbers in this assay, from the lowest: compounds 1, 2, 4 and 3 (each within the scatter of the next, the first and the last beyond it).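

In this assay, the new compound shows a 1.6-fold lower number from compound 3 to compound 4 (0.20 log units; within the scatter) and so does not separate 2-hydroxyethyl from tert-butyl on this aromatic carbon, although tert-butyl stood apart from both hydroxymethyl and butyl. The same group also shows a 1.4-fold higher number from compound 2 to compound 4 (0.15 log units; within the scatter) and a 1.5-fold higher number from compound 1 to compound 4 (0.17 log units; within the scatter), which leaves compound 4 within the scatter of all three other compounds and places it in the gap between compound 1 and compound 3. No measurement shown here gives a reason for these values.

On these data alone, it remains open whether an amine, a carboxylic acid or a longer hydroxyalkyl chain on this aromatic carbon would give a step beyond the scatter from compound 4. As far as these compounds go, a phenyl ring in the same place is equally open, and so the reach of the tert-butyl result remains undefined.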